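A few compounds are considered here, and "the series" means these few. Any claim that something is new, unique, unknown or untested is made for them only; others in the source may bear on it.

Measured so far in a functional assay on MCF7 cells (Homo sapiens) for antiproliferative activity, read by MTT assay, with a stated time of 24 h, tested at 100 uM; a higher number here means a weaker effect of the compound at the concentration tested, a lower number a stronger effect:
- compound 1 `OC(CCn1nc2c(Br)c(Br)c(Br)c(Br)c2n1)c1ccc(F)cc1`: 0%
- compound 2 `C[C@H](O)CCn1nc2c(Br)c(Br)c(Br)c(Br)c2n1`: 31%

Compound 1 holds the lowest of the two numbers, a reading of zero at the concentration tested, meaning the strongest effect seen so far in this assay. Its nearest neighbour in the numbers is compound 2, whose reading stands higher, a gap that lies beyond the scatter of repeated measurements. No pair of these two is set out as a single-point step, so only their two values are taken as shown.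

Compound 3 `CC(O)CCn1nc2c(Br)c(Br)c(Br)c(Br)c2n1` has not yet been measured in this assay. It differs from compound 1 in one place: methyl in place of 4-fluorophenyl on a saturated chain carbon bound to an oxygen on a saturated carbon and a saturated chain carbon. The shared core and the chain bearing the hydroxyl are kept; only the substituent on the carbinol carbon changes.

Without a measured step of this kind, the expected size of the move from compound 1 to compound 3 rests on the reference value of compound 2, which gives 31% in this assay. Compound 3 is therefore expected to land near that reference, a step upward a number 30 percentage points higher from compound 1 to compound 3 (beyond the scatter) from compound 1 that is estimated to lie beyond the scatter. The estimate for compound 3 in this assay is 30%, within 15% to 45%.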

Compound 3, a percentage reported as activity, at one concentration (the size of the read-out at that concentration, not a potency): 57%
The estimate for compound 3 lay 27 percentage points below the measured number; the measured number lies above the stated range.
By their numbers in this assay, from the lowest: compound 1; then compound 2; then compound 3.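

In this assay, methyl in place of 4-fluorophenyl on the saturated chain carbon bound to an oxygen gives a number 57 percentage points higher from compound 1 to compound 3 (beyond the scatter), the first direct single-place measure at this position, and it shows that the smaller group goes with a clearly weaker effect at the concentration tested. The methyl compounds do not share one reading, however: a number 26 percentage points higher from compound 2 to compound 3 (beyond the scatter), although the two have the same atoms and bonds. The size of the change from 4-fluorophenyl to methyl therefore depends on which methyl compound is taken, and the only structural difference between those two is in how they are drawn: the fact that one of compounds 2 and 3 is drawn with a defined configuration and the other without, at the place where they differ

The compounds shown leave open whether the reading of compound 1 goes with the aromatic ring or with its fluorine, and how an unsubstituted phenyl, a longer chain or an amine at the same carbon would read. Also open, going by these compounds, are the composition of compound 3, the reading of the opposite configuration at the stereocentre, and any role of configuration at the same carbon in compound 1.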